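Swapping the Fluorinated Carbinol for a Sulfonamide

A few compounds are considered here, and "the series" means these few. Any claim that something is new, unique, unknown or untested is made for them only; others in the source may bear on it.

In an assay on cells (Hepatocyte) for inhibition of glucokinase regulatory protein (Mus musculus), with stated times of 20 min and 40 min (on this read-out higher numbers stand for an effect only at larger amounts of compound and lower numbers for an effect already at smaller amounts), compound 1 `CC#C[C@H]1CN(S(=O)(=O)c2ccc(N)nc2)CCN1c1ccc(C(O)(CC#N)C(F)(F)F)cc1` gives 219 nM. Compound 2 `CC#C[C@H]1CN(S(=O)(=O)c2ccc(N)nc2)CCN1c1ccc(C(O)(C(F)(F)F)C(F)(F)F)cn1` gives 421 nM in this assay; the two numbers lie within the usual scatter of each other, so compound 1 is not set apart from compound 2 on these data. Compound 3 `CC#C[C@H]1CN(S(=O)(=O)c2ccc(N)nc2)CCN1c1ccc(S(=O)(=O)NCC2CC2)cc1` differs from compound 1 by a group of 8 heavy atoms (4 carbon, 1 nitrogen, 2 oxygen, 1 sulfur; one three-membered non-aromatic ring of carbon only) in place of a group of 9 heavy atoms (4 carbon, 1 nitrogen, 1 oxygen, 3 fluorine; no ring), on an aromatic carbon. For the measured compounds named here, no measured pair shares this kind of change, so its effect cannot be read from the data. For compound 3 a step of a 1.8-fold higher number from compound 1 to compound 3 (0.26 log units; within the scatter) is expected, most likely within or only modestly beyond the scatter. Compound 3 is therefore expected to give 400 nM in this assay, with a range from 100 nM to 2000 nM.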

Compound 3, half-maximal effective concentration: 271 nM
Compound 3: middle estimate off by 1.5-fold (0.17 log units), on the high side; low and high end bracket the measured number.
By their numbers in this assay, from the lowest: compounds 1, 3 and 2 (each within the scatter of the next).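

On the aromatic carbon para to a large group, replacing the fluorinated carbinol with (cyclopropylmethyl)sulfamoyl gives a 1.2-fold higher number from compound 1 to compound 3 (0.09 log units; within the scatter) in this assay. The earlier compounds shown here both carry fluorinated carbinols, so only this result shows that a group without fluorine, bearing a three-membered ring, can stand here with no step beyond the scatter. Nothing available explains this result.

Whether the cyclopropyl ring contributes to this remains open, since no shorter or longer chain on the sulfonamide nitrogen is shown. From the compounds shown here alone, what an amine or a carboxylic acid would give at this carbon also remains unknown.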